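The compounds below may be only part of what the source reports. "The series", "measured", "known", "first", "only" and "open" are said of these compounds alone.

Measured compounds in an assay on HL-60 cells for inhibition of glutathione S-transferase P (Homo sapiens); a lower number here means a stronger inhibitor, a higher number a weaker inhibitor:
compound 1, `C=C(C)C(=O)c1ccc(OCc2nc(C)no2)cc1C`: 5000 nM
compound 2, `C=C(C)C(=O)c1ccc(OCc2nc(-c3ccc([N+](=O)[O-])cc3)no2)cc1C`: 2900 nM
compound 3, `C=C(C)C(=O)c1ccc(OCc2nc(C)no2)c(C)c1C`: 4000 nM

Compound 3 sits within the usual scatter of both compound 1 and compound 2 in this assay; none of the three separates from the others beyond that scatter.

Compound 4 is `C=C(C)C(=O)c1ccc(OCc2nc(-c3ccc(C(F)(F)F)cc3)no2)c(C)c1C`. It differs from compound 3 in one place: 4-(trifluoromethyl)phenyl in place of methyl on an aromatic carbon. Among the compounds with values here, the only measured step bearing on this is the exchange of methyl for an aryl group at the same ring carbon, a 1.7-fold lower number from compound 1 to compound 2 (0.24 log units; within the scatter), which stayed within the scatter. Compound 4 is therefore expected to show a step of about a 1.3-fold lower number from compound 3 to compound 4 (0.12 log units; within the scatter) in this assay, a change not clearly beyond the scatter, tending if anything toward a lower number. The estimate for compound 4 is 3000 nM, with a range from 1500 nM to 6000 nM.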

Compound 4, half-maximal inhibitory concentration: 3900 nM
Estimate against measurement, compound 4: 1.3-fold (0.11 log units) below; the measured number falls inside the stated range.
By their numbers in this assay, from the lowest: compounds 2, 4, 3 and 1 (each within the scatter of the next).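

In this assay, 4-(trifluoromethyl)phenyl in place of methyl on the aromatic carbon between two ring nitrogen atoms gives a 1.0-fold lower number from compound 3 to compound 4 (0.01 log units; within the scatter). Thus a group of 10 heavy atoms at this position leaves the number within the scatter on the core of compound 3, and a second aryl group now joins the 4-nitrophenyl of compound 2 in showing no separation from methyl. No available data explain this result.

As far as these compounds go, whether an amine, a carboxylic acid or a longer alkyl chain at this carbon would behave the same remains open. Also open, from the compounds shown here alone, is whether any group here can move the number beyond the scatter.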